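The source may hold more compounds than are shown below. What is called first, only, known or untested is meant among the compounds shown, and "the series" means these compounds.

Compound 1 `COc1cc2ncnc(-n3cnc(-c4ccccn4)n3)c2cc1OC`: 30000 nM
Compound 2 `COc1cc2ncnc(-n3nc(-c4ccccn4)nc3N)c2cc1OCCCN1CC(C)OC(C)C1`: 8000 nM

Both values come from a physicochemical assay for solubility, in phosphate buffer, with a stated time of 18 h, at pH 7.4; on this read-out lower numbers stand for lower solubility and higher numbers for higher solubility. Compound 2 has the lower number of the two, and its gap to compound 1 lies beyond the scatter. Compound 3 `COc1cc2ncnc(-n3nc(-c4ccccn4)nc3N)c2cc1OCCCNC(=O)OC(C)C` differs from compound 2 in one place, on a saturated chain carbon, three bonds along the chain from an oxygen on an aromatic ring: (isopropoxycarbonyl)amino in place of 2,6-dimethylmorpholin-4-yl on a saturated chain carbon, three bonds along the chain from an oxygen on an aromatic ring. For the measured compounds named here, no measured pair shows what this swap does, so the expectation is uncertain, but a moderate fall beyond the scatter in this assay seems most likely. The expected change is a 2.7-fold lower number from compound 2 to compound 3 (0.43 log units; beyond the scatter). For compound 3 the estimate is 3000 nM, with an expected range of 800 nM to 9000 nM.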

Compound 3, solubility: 18000 nM
Estimate against measurement, compound 3: 6.0-fold (0.78 log units) below, and the stated range ends below it.
By their numbers in this assay, from the lowest: compound 2; then compounds 3 and 1 (each within the scatter of the next).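

In this assay, putting (isopropoxycarbonyl)amino in place of 2,6-dimethylmorpholin-4-yl on this saturated chain carbon gives a 2.3-fold higher number from compound 2 to compound 3 (0.35 log units; beyond the scatter) in a modest step. The group at the end of this propyl chain therefore does affect the read-out, and here the group without a ring gives the higher number. No supporting measurement explains the rise. Going by these compounds, it remains open how a primary amine or a carboxylic acid at this place would compare. On these data alone, a longer chain carrying the same (isopropoxycarbonyl)amino group also remains untested here.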